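Replacing acetoxy with methanesulfonamido: what happens to solubility?

The source may hold more compounds than are shown below. What is called first, only, known or untested is meant among the compounds shown, and "the series" means these compounds.

Measured in a physicochemical assay for solubility, read by HPLC, with a stated time of 24 h; on this read-out lower numbers stand for lower solubility and higher numbers for higher solubility:
Compound 1 `O=C1O[C@@H](CN2CCC(c3ccc(F)cc3)CC2)CN1c1ccc(-n2cc(-c3ccccn3)cn2)c(F)c1` gives <= 19400 nM as a limit, not a number
Compound 2 `O=C1CCC(=O)N1C[C@H]1CN(c2ccc(-n3cc(-c4ccccn4)cn3)c(F)c2)C(=O)O1` gives 45300 nM as a number
Compound 3 `CC(=O)OC[C@H]1CN(c2ccc(-n3cc(-c4ccccn4)cn3)c(F)c2)C(=O)O1` gives 373000 nM as a number

Of the two true numbers, compound 3 stands higher with 373000 nM and the nearest, compound 2, gives 45300 nM on the lower side. The value for compound 1 is only a limit, so it cannot be ranked as exactly.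

Compound 4 `CS(=O)(=O)NC[C@H]1CN(c2ccc(-n3cc(-c4ccccn4)cn3)c(F)c2)C(=O)O1` keeps the shared core and differs from compound 3 in one place: methanesulfonamido in place of acetoxy on a saturated chain carbon bound to a saturated ring carbon. In words, methanesulfonamido stands in place of acetoxy on a saturated chain carbon bound to a saturated ring carbon.

Among the measured compounds shown here, only one measured step bears on this place, namely an 8.2-fold higher number from compound 2 to compound 3 (0.92 log units; beyond the scatter) when acetoxy replaced 2,5-dioxopyrrolidin-1-yl. Here acetoxy leaves again, and compound 3 already sits at the top of the numbers, so a fall is the more likely direction. One step is thin support, so the expected fall is set smaller than that step and the range is kept wide. The expected change is a 3.4-fold lower number from compound 3 to compound 4 (0.53 log units; beyond the scatter) in this assay, towards a lower number. For compound 4 the estimate is 110000 nM with an expected range from 30000 nM to 350000 nM as its ends.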

Compound 4, solubility: 2300 nM
Compound 4: middle estimate off by 48-fold (1.68 log units), on the high side; measured number below the stated range.
By their numbers in this assay, from the lowest: compound 4; then compound 2; then compound 3.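

In this assay, among the compounds shown here, the place on a saturated chain carbon bound to a saturated ring carbon turns out to be far more sensitive than the earlier compounds could show: a 160-fold lower number from compound 3 to compound 4 (2.21 log units; beyond the scatter), a much larger step than the only earlier one there, an 8.2-fold higher number from compound 2 to compound 3 (0.92 log units; beyond the scatter). The 2,5-dioxopyrrolidin-1-yl group does not mark the bottom of the range either, since the new data show a 20-fold lower number from compound 2 to compound 4 (1.29 log units; beyond the scatter), so changing this one group with the shared core kept moves the number widely in both directions. Compound 1 gives <= 19400 nM, which is a limit and not a number, so its steps to the other compounds cannot be read.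

The data shown give no measured reason for the fall, even though the change brings in one hydrogen-bond donor that acetoxy lacks. Still open, as far as these compounds go, is whether the fall follows the nitrogen with its hydrogen or the sulfur with its two oxygens, a question that an acetamido group or an N-methyl methanesulfonamido group at this place could help to separate.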